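The source may hold more compounds than are shown below. What is called first, only, known or untested is meant among the compounds shown, and "the series" means these compounds.

Measured so far:
compound 1, `COc1cc(C(c2cc(OC)c(OC)c(OC)c2)[C@@H]2COC(=O)[C@H]2C)cc(OC)c1O`: > 316000 nM
compound 2, `COc1cc(C(c2cc(OC)c(OC)c(OC)c2)[C@@H]2COC(=O)[C@H]2C)cc(O)c1OC`: > 316000 nM

In a functional assay on A549 cells (Homo sapiens) for cytotoxicity, read by MTT assay, with a stated time of 24 h (a lower number here means a stronger inhibitor, a higher number a weaker inhibitor), compound 1 gives > 316000 nM, which is a limit of the assay rather than a number. In this assay compound 2 likewise gives > 316000 nM, again a limit and not a number. Compound 2 therefore stands at the limit of > 316000 nM in this assay, at which 2 of the 2 values shown sit; the numbers do not set it apart from compound 1, and neither compound shows measurable cytotoxicity here. Compound 3 `COc1cc(C(c2cc(OC)c(OC)c(OC)c2)[C@@H]2COC(=O)[C@H]2C)cc(OC)c1OC` has not yet been measured in this assay. It is compound 2 with methyl in place of hydrogen on an oxygen on an aromatic ring. No measured step of this kind exists among these compounds, so the size of the change cannot be read from a neighbour. With compound 2 at > 316000 nM, the step to compound 3 is expected to be none beyond the scatter. The step is estimated as a step that the limit leaves unreadable from compound 2 to compound 3. Compound 3 is estimated at 400000 nM, with a range from 150000 nM to 1500000 nM, and most likely only a limit will be reported.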

Compound 3, half-maximal inhibitory concentration: > 316000 nM
Compound 3: a limit, no number; the forecaster's own chance of this, stated with the estimate: 85%; the middle value does not contradict the limit.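

In this assay compound 3 gives > 316000 nM, again a limit of the assay and not a number. For the compounds shown here, no step from compound 1 or compound 2 to compound 3 can therefore be read. The compounds shown leave open whether going from hydroxy to methoxy changes cytotoxicity at all.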